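From benzyl to 3-phenylpropyl on compound 3

A few compounds are considered here, and "the series" means these few. Any claim that something is new, unique, unknown or untested is made for them only; others in the source may bear on it.

Compound 1 `COc1ccc(NC(=S)Nc2nc(C(=O)NCc3ccccc3)cs2)cc1` gives 39300 nM
Compound 2 `COc1ccc(NC(=S)Nc2nc(C(=O)NCCCc3ccccc3)cs2)cc1` gives 74500 nM
Compound 3 `O=C(NCc1ccccc1)c1csc(NC(=S)Nc2ccc(Cl)cc2)n1` gives 51300 nM

In a functional assay on PC-3 cells (Homo sapiens) for antiproliferative activity, read by MTT assay, with a stated time of 72 h (on this read-out lower numbers stand for stronger inhibition and higher numbers for weaker inhibition), compound 3 gives 51300 nM, which lies within the usual scatter of the values for compound 1 and compound 2, so the three cannot be put in any order.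

Compound 4 `O=C(NCCCc1ccccc1)c1csc(NC(=S)Nc2ccc(Cl)cc2)n1` differs from compound 3 in one place: phenethyl in place of phenyl on a saturated chain carbon bound to an amide-type nitrogen. Phenethyl stands in place of phenyl on a saturated chain carbon bound to an amide-type nitrogen.

The same swap has been measured once, with methoxy in place of chloro: a 1.9-fold higher number from compound 1 to compound 2 (0.28 log units; within the scatter). The swap of chloro for methoxy itself gave a 1.3-fold higher number from compound 1 to compound 3 (0.12 log units; within the scatter). Neither step leaves the scatter, and one pair is thin evidence.

A small rise in the number, probably no larger than the scatter, is therefore expected in this assay. The estimated change is a 1.6-fold higher number from compound 3 to compound 4 (0.19 log units; within the scatter). For compound 4 the expected value is 80000 nM, with an estimated range from 42000 nM to 150000 nM.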

Compound 4, half-maximal inhibitory concentration: 42400 nM
Beside the measured number, compound 4's estimate is 1.9-fold (0.28 log units) above it, within the range that was stated.
By their numbers in this assay, from the lowest: compounds 1, 4, 3 and 2 (each within the scatter of the next).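

Compound 4 means that the change from benzyl to 3-phenylpropyl, on a saturated chain carbon bound to an amide-type nitrogen, can now be read on two cores in this assay. The second reading is a 1.2-fold lower number from compound 3 to compound 4 (0.08 log units; within the scatter), and the two readings agree within the scatter: the same change on two cores in this assay, a 1.9-fold higher number (0.28 log units; within the scatter) from compound 1 to compound 2 and a 1.2-fold lower number (0.08 log units; within the scatter) from compound 3 to compound 4, 2.3-fold (0.36 log units) apart, within the scatter of two such steps. Chloro in place of methoxy on an aromatic carbon can also now be read twice, with a 1.8-fold lower number from compound 2 to compound 4 (0.24 log units; within the scatter) as the second reading, and again the two agree within the scatter: the same change on two cores in this assay, a 1.3-fold higher number (0.12 log units; within the scatter) from compound 1 to compound 3 and a 1.8-fold lower number (0.24 log units; within the scatter) from compound 2 to compound 4, 2.3-fold (0.36 log units) apart, within the scatter of two such steps.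

From the compounds shown here alone, neither change separates these four compounds, so the response of this position to a more different group remains unknown. An amine or a carboxylic acid on the chain, or a much longer chain, might still move the number beyond the scatter.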